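The source may hold more compounds than are shown below. What is called first, only, known or untested is meant among the compounds shown, and "the series" means these compounds.

The study follows four compounds that share a core and a 1-arylethyl group. Going by the values given here, compound 1 `CNC(=O)c1cc(C(=O)N[C@H]2[C@@H]3C[C@H](O)C[C@@H]32)n([C@@H](C)c2cccc(Cl)c2)n1` is the first of them. In a physicochemical assay for solubility, measured as kinetic solubility (on this read-out higher numbers stand for higher solubility and lower numbers for lower solubility), compound 1 gives >= 168 ug/mL, which is a limit of the assay rather than a number. Compound 2 `CNC(=O)c1cc(C(=O)N[C@H]2CC[C@H](O)CC2)n([C@@H](C)c2cccc(Cl)c2)n1` differs from compound 1 only in the group on the amide nitrogen. In this assay compound 2 gives >= 143 ug/mL, again a limit. Between them lies a step that the two limits leave unreadable from compound 1 to compound 2, so that single measured step carries no readable size. Compound 3 `CNC(=O)c1cc(C(=O)N[C@H]2CC[C@H](O)CC2)c([C@@H](C)c2cccc(C)c2)o1` has a different core and carries a 1-(3-methylphenyl)ethyl group. In this assay compound 3 gives >= 172 ug/mL, also a limit. Thus all three values sit at limits, (the limit of >= 143 ug/mL in this assay, at which 1 of the 3 values shown sits), the limit of >= 168 ug/mL in this assay, at which 1 of the 3 values shown sits, and (the limit of >= 172 ug/mL in this assay, at which 1 of the 3 values shown sits), and compound 3 cannot be ordered against the other two; it simply stands at the same ceiling as they do. Compound 4 `CNC(=O)c1cc(C(=O)N[C@H]2CC[C@H](O)CC2)c([C@@H](C)c2ccc(Cl)cc2)o1` differs from compound 3 by 4-chlorophenyl in place of 3-methylphenyl on a saturated chain carbon bound to an aromatic carbon and a saturated chain carbon. Among the compounds with values here, none of the measured steps touches the 1-(3-methylphenyl)ethyl group, and the only measured step is itself unreadable, so no size can be carried over to this change. Compound 4 is therefore expected to sit where compound 3 sits, with an expected step of an at least 1.1-fold lower number from compound 3 to compound 4 (0.05 log units; that floor lies within the scatter), that is, no change beyond the scatter and most likely another limit. The estimate for compound 4 is 150 ug/mL, with an expected range from 60 ug/mL to 200 ug/mL.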

Compound 4, solubility: >= 118 ug/mL
Compound 4 ended at the assay's limit; the forecaster's own chance of this, stated with the estimate: 65%; the middle value is on the limit's open side.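

In this assay compound 4 gives >= 118 ug/mL, which is a limit of the assay and not a number. Going by these compounds alone, compound 3 also stands at a limit, so no step from compound 3 to compound 4 can be read. The compounds shown leave open where the actual values of all four lie in this assay, and whether 1-(4-chlorophenyl)ethyl in place of 1-(3-methylphenyl)ethyl changes the read-out at all.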